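Swapping the aryl group on a cyanosulfanyl-bearing core

A few compounds are considered here, and "the series" means these few. Any claim that something is new, unique, unknown or untested is made for them only; others in the source may bear on it.

Compound 1 `Cc1ccc(-c2cn3nc(Cc4ccc(Cl)cc4)sc3n2)cc1` was tested in a functional assay on HeLa cells (Homo sapiens) for cytotoxicity, with a stated time of 72 h; on this read-out lower numbers stand for stronger inhibition and higher numbers for weaker inhibition. For compound 1 the result is a limit of the assay, > 250000 nM, at the limit of > 250000 nM in this assay, at which 1 of the 3 values shown sits. Compound 2 `Clc1ccc(Cc2nn3cc(-c4ccc(Cl)cc4Cl)nc3s2)cc1` carries 2,4-dichlorophenyl in place of 4-methylphenyl on an aromatic carbon and in this assay compound 2 gives 109000 nM, which amounts to an at least 2.2-fold lower number from compound 1 to compound 2 (0.36 log units; beyond the scatter). Compound 3 `Cc1ccc(-c2nc3sc(Cc4ccc(Cl)cc4)nn3c2SC#N)cc1` differs from compound 1 in cyanosulfanyl in place of hydrogen on an aromatic carbon, and this change brings an at least 11-fold lower number from compound 1 to compound 3 (1.05 log units; beyond the scatter), so that compound 3 gives 22000 nM, the lowest of the two numbers obtained.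

Compound 4 `N#CSc1c(-c2ccc(Cl)cc2Cl)nc2sc(Cc3ccc(Cl)cc3)nn12` has not yet been measured. It stands to compound 3 as compound 2 stands to compound 1, carrying (2,4-dichlorophenyl in place of 4-methylphenyl on an aromatic carbon). The surroundings are not identical, since in compound 4 the place is also next to the ring atom that bears a cyanosulfanyl group, so this is the same kind of change rather than the same change. Set beside the earlier at least 2.2-fold lower number from compound 1 to compound 2 (0.36 log units; beyond the scatter), the expectation in this assay is a 2.8-fold lower number from compound 3 to compound 4 (0.44 log units; beyond the scatter), resting on that first step. Compound 4 is accordingly estimated at 8000 nM, between 3000 nM and 25000 nM.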

Compound 4, half-maximal inhibitory concentration: 18000 nM
Beside the measured number, compound 4's estimate is 2.3-fold (0.35 log units) below it; low and high end bracket the measured number.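

On the core bearing cyanosulfanyl, 2,4-dichlorophenyl in place of 4-methylphenyl gives a 1.2-fold lower number from compound 3 to compound 4 (0.09 log units; within the scatter) in this assay, and set beside the same exchange on the core without that group, the size of the two steps cannot be compared: the same change on two cores in this assay, an at least 2.2-fold lower number (0.36 log units; beyond the scatter) from compound 1 to compound 2 and a 1.2-fold lower number (0.09 log units; within the scatter) from compound 3 to compound 4; the limit leaves it open whether they differ

The cyanosulfanyl change goes the same way with both aryl groups, with a 6.1-fold lower number from compound 2 to compound 4 (0.78 log units; beyond the scatter) for the 2,4-dichlorophenyl pair, but here too the two sizes cannot be set against each other: the same change on two cores in this assay, an at least 11-fold lower number (1.05 log units; beyond the scatter) from compound 1 to compound 3 and a 6.1-fold lower number (0.78 log units; beyond the scatter) from compound 2 to compound 4; the limit leaves it open whether they differ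

The value of compound 1, > 250000 nM, is a limit of the assay, so the steps show neither that the aryl exchange carries over from one core to the other nor that it fails to do so.

The compounds shown leave open whether an amine or a carboxylic acid in place of cyanosulfanyl on that aromatic carbon would give a number in the same range. They also leave open how a methoxy group on the phenyl ring in place of the chlorines would read on either core.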